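This account rests on a few compounds, and the source may have more. Where it says the series, first, only, none or still open, it means among the compounds named here.

Measured so far in a functional assay (brain) for inhibition, with Rattus norvegicus as the target; a higher number here means a weaker inhibitor, a lower number a stronger inhibitor:
- compound 1 `Fc1ccc2[nH]cc(CCCCN3CCNCC3)c2c1` gives 0.15 nM
- compound 2 `N#Cc1ccc2[nH]cc(C3CCNCC3)c2c1` gives 58 nM

Compound 2, at 58 nM in this assay, holds the higher of the two numbers, which makes it the weaker inhibitor of the pair. Its gap to compound 1 lies beyond the scatter.

The compound awaiting measurement is compound 3 `NC(=O)c1ccc2[nH]cc(C3CCNCC3)c2c1`, which carries carbamoyl in place of cyano on an aromatic carbon of a six-membered aromatic ring of carbon only. The rest of the structure of compound 2 stays unchanged.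

Within the data shown here, no two measured compounds differ in one place only, so the series gives no direct guide to the size of this exchange. On this limited basis, no step beyond the scatter is expected in this assay, in either direction, though the uncertainty is wide. The expectation rests on compound 2 at 58 nM as its only close reference. The estimated change is a 1.2-fold lower number from compound 2 to compound 3 (0.06 log units; within the scatter) and would stay within the scatter. For compound 3 the estimate is 50 nM as the expected value, with an expected range from 8 nM to 300 nM for repeat measurements.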

Compound 3, half-maximal inhibitory concentration: > 100 nM
Compound 3: a limit, no number; the forecaster's own chance of this, stated with the estimate: 5%; at least 2.0-fold (0.30 log units) between middle value and limit.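

In this assay compound 3 gives > 100 nM, which is a limit of the assay and not a number. Carbamoyl in place of cyano on this aromatic carbon, the first exchange in the series that can be read in one place, gives an at least 1.7-fold higher number from compound 2 to compound 3 (0.23 log units; that floor lies within the scatter), so the change adds a hydrogen-bond donor and replaces a triple bond with a double bond without any gain in inhibition being seen, although the floor alone does not establish a loss beyond the scatter. The step therefore has a lower bound but no upper bound, and its true size cannot be read: the limit of > 100 nM in this assay, at which 1 of the 3 values shown sits.

Going by these compounds, whether a carboxylic acid or an amine on this aromatic carbon would track with cyano or with carbamoyl remains open. Compound 1 differs from compound 2 in more than one place, so the compounds shown do not separate the contribution of the group on this carbon from that of the longer chain carried by compound 1.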